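A few compounds are considered here, and "the series" means these few. Any claim that something is new, unique, unknown or untested is made for them only; others in the source may bear on it.

Among the measured compounds shown here, compound 2 `CC(C)C(c1ccc(-c2ccc3cccc(F)c3c2)[nH]c1=O)C1C(=O)NC(=O)N1C` is the one member of this group with a number rather than a limit in an ADME assay on microsomes from liver (Rattus norvegicus) for metabolic stability (on this read-out lower numbers stand for a shorter-lived compound and higher numbers for a longer-lived compound), where compound 2 gives 0.263 h. Compound 1 `CCC(CC)C(/C=C1\OC(=O)NC1=O)c1ccc(-c2ccc3cccc(F)c3c2)[nH]c1=O` reaches a limit of the assay, with > 3 h in this assay. Compound 3 `CCC(/C=C1\OC(=O)NC1=O)(CC)c1ccc(-c2ccc3cccc(F)c3c2)[nH]c1=O` likewise reaches a limit, recorded as > 3 h in this assay. For the measured compounds named here, the only evidence on the measured compounds is the limit of > 3 h in this assay, at which 2 of the 3 values shown sit. Compound 4 `CC(C)C(CC1NC(=O)NC1=O)c1ccc(-c2ccc3cccc(F)c3c2)[nH]c1=O` has not been measured; it differs from compound 2 by (2,5-dioxoimidazolidin-4-yl)methyl in place of 3-methyl-2,5-dioxoimidazolidin-4-yl on a saturated chain carbon bound to an aromatic carbon and a saturated chain carbon. Going by the values given here, no measured pair shows this change, so only a modest lengthening, at the edge of the scatter, is expected in this assay. Compound 4 is therefore estimated to give 0.6 h, with a likely range from 0.2 h to 2 h, the expected step being a 2.3-fold higher number from compound 2 to compound 4 (0.36 log units; beyond the scatter).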

Compound 4, half-life: 0.35 h
For compound 4 the middle estimate is 1.7-fold (0.23 log units) above the measured one; measured number inside the range.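

In this assay, placing (2,5-dioxoimidazolidin-4-yl)methyl where 3-methyl-2,5-dioxoimidazolidin-4-yl stood on this saturated chain carbon gives a 1.3-fold higher number from compound 2 to compound 4 (0.12 log units; within the scatter). Here the same atoms, joined differently and with one more hydrogen-bond donor in the entering group, leave the half-life within the scatter. Neither compound 2 nor compound 4 reaches the limit recorded for other members of the group: the limit of > 3 h in this assay, at which 2 of the 4 values shown sit.

The compounds shown leave open whether an amine or a carboxylic acid at this position would give a different half-life. They also do not show which structural difference goes with the limit values.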